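Isopropyl to Ethyl on the Only Measured Number

This account rests on a few compounds, and the source may have more. Where it says the series, first, only, none or still open, it means among the compounds named here.

Going by the values given here, in a functional assay on 4T1 cells (Homo sapiens) for cytotoxicity, read by MTT assay, with a stated time of 48 h (a higher number here means a weaker inhibitor, a lower number a stronger inhibitor), compound 1 (`CC(C)n1c(/C=C2/C(=O)Nc3ccc(Br)cc32)nc2ccccc21`) gives 5960 nM as the only true number so far. Compound 2 (`CCn1c(/C=C2/C(=O)Nc3ccccc32)nc2ccccc21`) sits at > 50000 nM as a limit, not a number. Compound 3 (`Cn1c(/C=C2/C(=O)Nc3ccc([N+](=O)[O-])cc32)nc2ccccc21`) sits at > 50000 nM as a limit too. Among the compounds with values here, the data therefore hold the limit of > 50000 nM in this assay, at which 2 of the 3 values shown sit, and no measured step between closely matched compounds.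

Compound 4 (`CCn1c(/C=C2/C(=O)Nc3ccc(Br)cc32)nc2ccccc21`) has not yet been measured. It differs from compound 1 by one small edit (hydrogen in place of methyl on a saturated chain carbon bound to an aromatic nitrogen and a saturated chain carbon), with hydrogen in place of methyl on a saturated chain carbon bound to an aromatic nitrogen and a saturated chain carbon, so isopropyl becomes ethyl.

The ethyl group also appears on compound 2 at the limit > 50000 nM and this tilts the expectation toward weaker inhibition. The expected change is a 2.3-fold higher number from compound 1 to compound 4 (0.37 log units; beyond the scatter) in this assay and would be a modest weakening. Compound 4 is estimated at 14000 nM within a range of 5000 nM to 45000 nM for now.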

Compound 4, half-maximal inhibitory concentration: 40700 nM
Compound 4: middle estimate off by 2.9-fold (0.46 log units), on the low side; the measured number falls inside the stated range.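

Going by these compounds alone, this is the first measured step at this position: with the bromo group kept, isopropyl to ethyl gives a 6.8-fold higher number from compound 1 to compound 4 (0.83 log units; beyond the scatter) in this assay. Losing a single methyl from the chain is therefore enough to move the number beyond the usual scatter, at least on this bromo-bearing compound. The bromo change is far less informative, since an at least 1.2-fold lower number from compound 2 to compound 4 (0.08 log units; that floor lies within the scatter) shows no clear gain or loss, because compound 2 carries a limit and not a number: the limit of > 50000 nM in this assay, at which 2 of the 4 values shown sit.

As far as these compounds go, whether a larger group in place of isopropyl, such as tert-butyl, cyclopentyl or a longer butyl chain, would give a lower number remains open. Also open, from the compounds shown here alone, is whether the isopropyl group has the same effect without the bromo group, or with a different group such as chloro in its place.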